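From Azetidine Amide to Open Amine Chain

This account rests on a few compounds, and the source may have more. Where it says the series, first, only, none or still open, it means among the compounds named here.

In a functional assay on Ishikawa cells (Homo sapiens) for antiproliferative activity, read by CCK-8 assay, with a stated time of 48 h (a lower number here means a stronger inhibitor, a higher number a weaker inhibitor), compound 1 `C/C=C/C(=O)N1CC(Oc2ccc(Oc3c(-c4ccc(F)cc4)sc4cc(O)ccc34)cc2)C1` gives 9400 nM while compound 2 `O=C(/C=C/CN1CC(Oc2ccc(Oc3c(-c4ccc(F)cc4)sc4cc(O)ccc34)cc2)C1)N1CCC1` gives 5450 nM so the two stand within the scatter of each other. Compound 3 `O=C(/C=C/CNCCOc1ccc(Oc2c(-c3ccc(F)cc3)sc3cc(O)ccc23)cc1)N1CCC1` differs from compound 1 by one change 2-((3-((azetidin-1-yl)carbonyl)prop-2-en-1-yl)amino)ethyl in place of 1-((prop-1-en-1-yl)carbonyl)azetidin-3-yl on an oxygen on an aromatic ring in which 2-((3-((azetidin-1-yl)carbonyl)prop-2-en-1-yl)amino)ethyl replaces 1-((prop-1-en-1-yl)carbonyl)azetidin-3-yl on an oxygen on an aromatic ring. Going by the values given here, the one measured step that bears on it is a 1.7-fold lower number from compound 1 to compound 2 (0.24 log units; within the scatter) and that step brings in the same 3-((azetidin-1-yl)carbonyl)prop-2-en-1-yl group. No step beyond the scatter is therefore expected in this assay and the estimated step is a 1.6-fold lower number from compound 1 to compound 3 (0.19 log units; within the scatter) at most modestly. Compound 3 is expected at 6000 nM with an estimated range from 2000 nM to 15000 nM as its span.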

Compound 3, half-maximal inhibitory concentration: 6560 nM
Beside the measured number, compound 3's estimate is 1.1-fold (0.04 log units) below it; the range from low to high includes it.
By their numbers in this assay, from the lowest: compounds 2, 3 and 1 (each within the scatter of the next).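

In this assay, putting 2-((3-((azetidin-1-yl)carbonyl)prop-2-en-1-yl)amino)ethyl in place of 1-((prop-1-en-1-yl)carbonyl)azetidin-3-yl on an oxygen on an aromatic ring gives a 1.4-fold lower number from compound 1 to compound 3 (0.16 log units; within the scatter). This position therefore tolerates an open amine chain, which adds a hydrogen-bond donor, in place of the azetidine ring attached to that oxygen, with no step beyond the scatter. No supporting data bear on why these numbers stay so close. As far as these compounds go, it remains open whether a longer chain, a methyl-substituted amine or a pyrrolidine amide at this position would move the number beyond the scatter.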